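A few compounds are considered here, and "the series" means these few. Any claim that something is new, unique, unknown or untested is made for them only; others in the source may bear on it.

Of the compounds shown here, two sharing one core have been tested in a functional assay on UACC-62 cells (Homo sapiens) for cytotoxicity, read by sulforhodamine B assay, with a stated time of 48 h, tested at 0.01 uM; a higher number here means a weaker effect of the compound at the concentration tested, a lower number a stronger effect. Compound 1 `COc1cc(C)cc(-c2c(-c3ccnc(-c4ccc(C(C)=O)cc4)c3)cnn2CC#N)c1` gives 88% in this assay, and compound 2 `COc1cc(C)cc(-c2nn(CC#N)cc2-c2ccc(-c3cccc(C(C)=O)c3)nc2)c1` gives 90%. These two numbers lie within the usual scatter of each other, so neither compound can be called stronger or weaker than the other; both point to a weak effect at the concentration tested.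

Compound 3 `COc1cc(C)cc(-c2c(-c3ccnc(-c4ccc(N(C)C)cc4)c3)cnn2CC#N)c1` has not yet been measured. It differs from compound 1 in a single place: dimethylamino in place of acetyl on an aromatic carbon, the new group standing on an aromatic carbon of a six-membered aromatic ring of carbon only, para to a large group. Going by the values given here, no pair of measured compounds shows what this swap does here, so the step of a number 2 percentage points higher from compound 1 to compound 3 (within the scatter) is expected to be small, staying within the scatter. Compound 3 is therefore expected to give about 90% in this assay, within a range from 76% to 102%.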

Compound 3, a percentage reported as activity, at one concentration (the size of the read-out at that concentration, not a potency): 38%
Beside the measured number, compound 3's estimate is 52 percentage points above it, and the stated range ends above it.
By their numbers in this assay, from the lowest: compound 3; then compounds 1 and 2 (each within the scatter of the next).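

In this assay, the change from 4-acetylphenyl to 4-(dimethylamino)phenyl brings a number 50 percentage points lower from compound 1 to compound 3 (beyond the scatter) and so shows that the effect depends strongly on the group at this place, para to a large group. Going by these compounds alone, compound 1 and compound 2 could not show this, since no single-place step linked them. The leaving and entering groups match in heavy atoms and hydrogen-bond acceptors, and neither carries a net charge, so these counts do not separate them, and nothing measured here explains the step.

On these data alone, it remains open whether a simple amino group, methylamino or a ring amine such as morpholine would give a similar result at this place. As far as these compounds go, it is also open whether dimethylamino would have a similar effect on the core of compound 2.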